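This account rests on a few compounds, and the source may have more. Where it says the series, first, only, none or still open, it means among the compounds named here.

Within the data shown here, compound 1 `CCNC(=O)c1nc(-c2cc(OC)c(OC)c(OC)c2)n(-c2ccc(OC)cc2)n1` gives 68% in a functional assay on the whole organism for inhibition, with Rattus norvegicus as the target, read by paw edema, with stated times of 30 min and 2 h, at a dose of 0.28 mmol/kg by the oral route (on this read-out lower numbers stand for less inhibition and higher numbers for more inhibition at the one dose given (going by the name of the read-out)), the highest of the three numbers so far. Compound 2 `COc1ccc(NC(=O)c2nc(-c3cc(OC)c(OC)c(OC)c3)n(-c3ccc(OC)cc3)n2)cc1` gives 45% and compound 3 `COc1ccc(-n2nc(C(=O)Nc3cccc(F)c3)nc2-c2cc(OC)c(OC)c(OC)c2)cc1` gives 67% in this assay. Both were built from compound 1 by placing an aromatic ring on the amide-type nitrogen: the change to compound 2 gave a number 23 percentage points lower from compound 1 to compound 2 (beyond the scatter), whereas the change to compound 3 gave a number 1 percentage points lower from compound 1 to compound 3 (within the scatter). Compound 4 `COc1ccc(-n2nc(C(=O)Nc3ccc(C(F)(F)F)cc3)nc2-c2cc(OC)c(OC)c(OC)c2)cc1` differs from compound 1 by 4-(trifluoromethyl)phenyl in place of ethyl on an amide-type nitrogen. These two steps bear on it, and they point in different directions, one a modest fall and one no change beyond the scatter. A small drop or none is therefore expected, a number 8 percentage points lower from compound 1 to compound 4 (within the scatter). The estimate for compound 4 in this assay is 60%, expected to lie between 44% and 74%.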

Compound 4, a percentage reported as inhibition, in the whole organism at one dose (the size of the read-out at that dose, not a potency): 55%
Estimate against measurement, compound 4: 5 percentage points above; measured number inside the range.
By their numbers in this assay, from the lowest: compounds 2 and 4 (each within the scatter of the next); then compounds 3 and 1 (each within the scatter of the next).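

In this assay, 4-(trifluoromethyl)phenyl in place of ethyl gives a number 13 percentage points lower from compound 1 to compound 4 (beyond the scatter) and so joins 4-methoxyphenyl in falling short of ethyl, while compound 3 remains the one aryl amide level with compound 1. Changing only the ring, a number 12 percentage points lower from compound 3 to compound 4 (beyond the scatter) shows that an aromatic ring on this nitrogen does not by itself settle the number. Trifluoromethyl in place of methoxy gives a number 10 percentage points higher from compound 2 to compound 4 (within the scatter) and so does not separate these two ring substituents. No measurement shown explains these differences. Going by these compounds, whether a propyl chain or a benzyl group on this nitrogen would hold the number of compound 1 stays open.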